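Acetylenic uracil diols: tert-butyl replacing difluorophenyl

A few compounds are considered here, and "the series" means these few. Any claim that something is new, unique, unknown or untested is made for them only; others in the source may bear on it.

Working notes on the series. Compound 1 (`CCCCCc1ccc(C#Cc2cn(CCC(COC(C)=O)COC(C)=O)c(=O)n(C(=O)c3ccccc3)c2=O)cc1`) reaches only the limit of the assay in a functional assay on SW-620 cells (Homo sapiens) for antiproliferative activity, read by MTT assay, with a stated time of 72 h (a lower number here means a stronger inhibitor, a higher number a weaker inhibitor), giving > 100000 nM. Compound 2 (`O=c1[nH]c(=O)n(CCC(CO)CO)cc1C#Cc1cc(F)cc(F)c1`) likewise sits at a limit in this assay, with > 100000 nM. On the numbers shown, compound 2 therefore has no measured position within range: both values shown are limits, see (the limit of > 100000 nM in this assay, at which 2 of the 2 values shown sit), and no step between measured compounds exists to calibrate the change.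

Compound 3 (`CC(C)(C)C#Cc1cn(CCC(CO)CO)c(=O)[nH]c1=O`) differs from compound 2 by tert-butyl in place of 3,5-difluorophenyl on a triple-bonded carbon, in words tert-butyl in place of 3,5-difluorophenyl on a triple-bonded carbon. Among the compounds with values here, with no measured step to lean on and compound 2 at > 100000 nM, no movement beyond the scatter is expected in either direction; the expected step of a number no higher from compound 2 to compound 3 (the limit leaves the size open) is essentially none. Compound 3 is thus estimated at 100000 nM, within 30000 nM to 300000 nM, most likely reported again only as a limit.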

Compound 3, half-maximal inhibitory concentration: > 100000 nM
Compound 3: a limit, no number; the forecaster's own chance of this, stated with the estimate: 80%; the middle value sits exactly at the limit.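

Within the data shown here, compound 3 sits at a limit, as compound 2 does, so no step from compound 2 to compound 3 can be read: the limit of > 100000 nM in this assay, at which 3 of the 3 values shown sit.

The compounds shown leave open how tert-butyl and 3,5-difluorophenyl compare in this assay and what concentration would give a measured value for any of them.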